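Replacing Acetyl with 3-Chlorophenylcarbonyl in Compound 1

The compounds below may be only part of what the source reports. "The series", "measured", "known", "first", "only" and "open" are said of these compounds alone.

Compound 1 `CC(=O)N1c2ccccc2CCC1C(=O)Nc1ccccc1O`: 54500 nM
Compound 2 `CC(=O)N1c2ccccc2CCC1C(=O)Nc1ccccc1C(F)(F)F`: > 80000 nM

Among the measured compounds shown here, in a functional assay on HCT-15 cells (Homo sapiens) for cytotoxicity, read by sulforhodamine B assay, with a stated time of 72 h (a lower number here means a stronger inhibitor of growth, a higher number a weaker inhibitor of growth), compound 1 gives 54500 nM, the only plain number here. Compound 2 gives only a limit of the assay, > 80000 nM. For the measured compounds named here, the one measured step, an at least 1.4-fold higher number from compound 1 to compound 2 (0.16 log units; that floor lies within the scatter), alters a different part of the shared core and so says little about the change toward compound 3 `O=C(Nc1ccccc1O)C1CCc2ccccc2N1C(=O)c1cccc(Cl)c1`, which is 3-chlorophenyl in place of methyl on a carbonyl carbon. Going by the values given here, no measured step bears on this change, so its direction is open. Compound 3 is expected at about 30000 nM, within 8000 nM to 80000 nM. The expected step, a 1.8-fold lower number from compound 1 to compound 3 (0.26 log units; within the scatter), is an estimate, not a measurement.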

Compound 3, concentration for 50% growth inhibition: 23100 nM
Estimate against measurement, compound 3: 1.3-fold (0.11 log units) above, and the stated range covers the measured number.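

In this assay, the group on the carbonyl carbon attached to the amide-type nitrogen in a ring affects growth inhibition: 3-chlorophenyl in place of methyl gives a 2.4-fold lower number from compound 1 to compound 3 (0.37 log units; beyond the scatter). Unlike the earlier step, this one ends on a plain number and can be read as a measured size. Compound 2, by contrast, gives only a limit of the assay: the limit of > 80000 nM in this assay, at which 1 of the 3 values shown sits.

As far as these compounds go, whether plain phenyl without the chlorine would read the same stays open. So does the effect of a longer chain such as propyl, or of an amine, on this carbonyl carbon.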